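Bromo in place of a dihydroxypropoxy chain on a flavone core

This account rests on a few compounds, and the source may have more. Where it says the series, first, only, none or still open, it means among the compounds named here.

Measured so far:
compound 1, `COc1cc(OC)c2c(=O)cc(-c3ccc(OCCCN)cc3)oc2c1`, 22%;
compound 2, `COc1cc(OC)c2c(=O)cc(-c3ccc(OCC(O)CO)cc3)oc2c1`, "not active" (no number reported).

Two compounds share the same core and differ only in the group on the pendant phenyl ring. In a functional assay (Homo sapiens) for antiproliferative activity, read by resazurin assay, with a stated time of 48 h, tested at 5 uM (on this read-out lower numbers stand for a weaker effect and higher numbers for a stronger effect at the one concentration tested), compound 1 gives 22%. In the same test compound 2 is reported as "not active" (no number reported), so no single number stands for it; it can only be said that no measurable effect was recorded. Compound 3, `COc1cc(OC)c2c(=O)cc(-c3ccc(Br)cc3)oc2c1`, has not been tested. It differs from compound 2 by bromo in place of 2,3-dihydroxypropoxy on an aromatic carbon. Among the measured compounds shown here, no comparable step between measured compounds is available, so the size and direction of the effect of this change cannot be read from the data. With so little to lean on, an estimate for compound 3 in this assay stays close to the modest effect seen for compound 1: compound 3 is expected to give about 20%, within the range 0% to 45%.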

Compound 3, a percentage reported as inhibition, at one concentration (the size of the read-out at that concentration, not a potency): 12%
The estimate for compound 3 lay 8 percentage points above the measured number; the measured number falls inside the stated range.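

Replacing the 3-aminopropoxy chain with bromo gives a number 10 percentage points lower from compound 1 to compound 3 (within the scatter) in this assay, so this test does not tell the two groups apart, and the small effect of compound 1 does not depend on keeping that amine-bearing chain on this aromatic carbon. Compound 2 is recorded as "not active" (no number reported), whereas compound 3 gives 12%; with no number for compound 2, the size of the change from 2,3-dihydroxypropoxy to bromo cannot be read. Nothing available explains these results.

The compounds shown leave open how a carboxylic acid or a longer amine-bearing chain on the same carbon would read in this assay. They also leave open whether compound 1 and compound 3 would still match at other concentrations, since a single concentration gives the size of an effect and not a potency.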